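The source may hold more compounds than are shown below. What is called first, only, known or untested is meant among the compounds shown, and "the series" means these compounds.

In a functional assay on NCI-H1975 cells (Homo sapiens) for cytotoxicity, read by CCK-8 assay, with a stated time of 72 h (on this read-out higher numbers stand for weaker inhibition and lower numbers for stronger inhibition), compound 1 `C=CCn1c(=O)/c(=C\c2cccc(Cl)c2)[nH]c(=O)/c1=C\c1ccccc1OC` gives 5100 nM, the lowest of the two numbers obtained so far in this series; compound 2 `COc1ccccc1/C=c1/[nH]c(=O)/c(=C\c2ccccc2OC)n(C)c1=O` gives 16900 nM, a higher number that lies beyond the scatter of the assay. Compound 3 `C=CCn1c(=O)/c(=C\c2cccc(F)c2)[nH]c(=O)/c1=C\c1ccccc1OC` remains to be measured in this assay. It differs from compound 1 by fluoro in place of chloro on an aromatic carbon. Going by the values given here, no pair of measured compounds isolates this change, so the step is expected to be small, a 1.5-fold higher number from compound 1 to compound 3 (0.17 log units; within the scatter), toward a slightly higher number and probably within the scatter. Compound 3 is estimated at 7500 nM, within a range from 3000 nM to 19000 nM.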

Compound 3, half-maximal inhibitory concentration: 25600 nM
Compound 3: middle estimate off by 3.4-fold (0.53 log units), on the low side; measured number above the stated range.
By their numbers in this assay, from the lowest: compound 1; then compounds 2 and 3 (each within the scatter of the next).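

In this assay, going by these compounds alone, the change from 3-chlorophenyl to 3-fluorophenyl is not silent: fluoro in place of chloro gives a 5.0-fold higher number from compound 1 to compound 3 (0.70 log units; beyond the scatter) and is the first step to isolate a single place. This position on the aromatic ring therefore responds to the exchange of one halogen for another, with chloro carrying the lower number of the two. No measurement at hand gives a reason for the step. Going by these compounds, whether bromo, methyl or an amine at this position would give a number nearer that of chloro or of fluoro stays open. So does whether the step keeps its size with changes elsewhere on the shared core.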